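From Compound 2 to Compound 3: One Group Exchanged

A few compounds are considered here, and "the series" means these few. Any claim that something is new, unique, unknown or untested is made for them only; others in the source may bear on it.

Measured so far in a functional assay on HepG2 cells (Homo sapiens) for cytotoxicity, read by MTT assay, with a stated time of 72 h; a lower number here means a stronger inhibitor, a higher number a weaker inhibitor:
- Compound 1 `CC1CCN(c2ccc(Nc3ncc4nc(Nc5ccccc5)n(C5CCCC5)c4n3)cc2)CC1`: > 5000 nM
- Compound 2 `C#Cc1cccc(Nc2nc3cnc(Nc4ccc(N5CCN(C)CC5)cc4)nc3n2C2CCCC2)c1`: 4900 nM

The entry for compound 1, > 5000 nM, is a limit of the assay and not a number. For the measured compounds named here, compound 2, at 4900 nM, therefore holds the only true number so far, which leaves nothing exact to rank it against.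

The next compound, compound 3 `CN1CCN(c2ccc(Nc3ncc4nc(Nc5ccc(Br)cc5)n(C5CCCC5)c4n3)cc2)CC1`, has 4-bromophenyl in place of 3-ethynylphenyl on a nitrogen on an aromatic ring. Going by the values given here, no measured pair shows what this exchange does, so no step beyond the usual scatter is expected in this assay, in either direction. The expected change a 1.1-fold lower number from compound 2 to compound 3 (0.04 log units; within the scatter) is correspondingly small. Like compound 1, compound 3 could also return only a limit. The estimated value for compound 3 is 4500 nM, with an expected range from 1500 nM to 12000 nM.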

Compound 3, half-maximal inhibitory concentration: > 5000 nM
Compound 3: no number, only a limit; the forecaster's own chance of this, stated with the estimate: 45%; at least 1.1-fold (0.04 log units) between middle value and limit.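

In this assay compound 3 gives > 5000 nM, which is a limit of the assay and not a number. Putting 4-bromophenyl in place of 3-ethynylphenyl on a nitrogen on an aromatic ring therefore gives an at least 1.0-fold higher number from compound 2 to compound 3 (0.00 log units; that floor lies within the scatter), and that floor is all that can be read of this change. This first exchange at the position shows no number lower than the one already held by compound 2, but the true size of the step stays unknown because the reading for compound 3 ends at the same limit as another value shown: the limit of > 5000 nM in this assay, at which 2 of the 3 values shown sit.

From the compounds shown here alone, whether an amine or a carboxylic acid on this phenyl ring would give a true number remains open. A comparison of 3-bromophenyl with 4-bromophenyl would also be needed to separate the effect of the bromine from that of where it sits.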